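This account rests on a few compounds, and the source may have more. Where it says the series, first, only, none or still open, it means among the compounds named here.

Compound 3 `CN(C)C(=O)c1cc2cnc(Nc3ccc(NC(=O)C4(C(=O)Nc5ccc(Br)cc5)CC4)cc3)nc2n1C1CCCC1` gives 87.8% in a functional assay on OVCAR-5 cells (Homo sapiens) for inhibition, read by CCK-8 assay, with a stated time of 72 h, tested at 10 uM (on this read-out higher numbers stand for more inhibition of growth at the one concentration tested and lower numbers for less inhibition of growth), the highest of the three numbers measured, although its margin over compound 2 `CN(C)C(=O)c1cc2cnc(Nc3ccc(NC(=O)C4(C(=O)Nc5cccc(O)c5)CC4)cc3)nc2n1C1CCCC1`, which gives 86%, is within the scatter; compound 1 `CN(C)C(=O)c1cc2cnc(Nc3ccc(NC(=O)C4(C(=O)Nc5ccccc5)CC4)cc3)nc2n1C1CCCC1` gives 77.1%. Compound 4 `CN(C)C(=O)c1cc2cnc(Nc3ccc(NC(=O)C4(C(=O)Nc5ccc(Cl)c(C(F)(F)F)c5)CC4)cc3)nc2n1C1CCCC1` has not yet been measured. 4-chloro-3-(trifluoromethyl)phenyl in place of 4-bromophenyl on an amide-type nitrogen The measured steps that bear on this both alter the same phenyl ring: a number 10.7 percentage points higher from compound 1 to compound 3 (beyond the scatter), and a number 1.8 percentage points higher from compound 2 to compound 3 (within the scatter). Among the compounds with values here, no measured step swaps one halogen for another or introduces a trifluoromethyl group, so the change from compound 3 to compound 4 is expected to stay within the scatter, with a number 1.8 percentage points lower from compound 3 to compound 4 (within the scatter). Compound 4 is therefore estimated at 86%, within a range from 74% to 95%.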

Compound 4, percent growth inhibition at one concentration: 48%
Beside the measured number, compound 4's estimate is 38 percentage points above it; the whole stated range lies above it.
By their numbers in this assay, from the lowest: compound 4; then compounds 1, 2 and 3 (each within the scatter of the next, the first and the last beyond it).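

In this assay this amide-type nitrogen proves sensitive to the ring it carries, with a number 39.8 percentage points lower from compound 3 to compound 4 (beyond the scatter) and a number 38 percentage points lower from compound 2 to compound 4 (beyond the scatter) as well as a number 29.1 percentage points lower from compound 1 to compound 4 (beyond the scatter) and so the plain phenyl ring ends up ahead of the new group. Among compounds 1, 2 and 3, changing this ring raised the number or left it within the scatter, so this is the first sign that a substituted ring can lower it. No evidence here explains the loss. The compounds shown do not separate chloro from trifluoromethyl, since a ring with 3-trifluoromethyl alone or 4-chloro alone is absent. As far as these compounds go, how an amine or a carboxylic acid on this ring would read also stays open.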